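Swapping Methyl for Hydroxy Next to the Ring Nitrogen

A few compounds are considered here, and "the series" means these few. Any claim that something is new, unique, unknown or untested is made for them only; others in the source may bear on it.

Compound 2 `Cc1ccc2ccc(NC(=O)c3ccc(-c4ccccc4)cc3)cc2n1` stands lowest of the two numbers measured in a functional assay for antagonist activity at transient receptor potential cation channel subfamily V member 1 (Homo sapiens), read by FLIPR and calcium flux (a higher number here means a more potent compound, by a factor of ten per unit of this negative logarithm, a lower number a less potent compound), where compound 2 gives 8. Its nearest neighbour is compound 1 `O=C(Nc1ccc2cccnc2c1)c1ccc(-c2ccccc2)cc1`, which in this assay gives 9.4. Going by the values given here, the only step joining the two is a number 1.40 log units lower from compound 1 to compound 2 (beyond the scatter), a change that lies well beyond the scatter. Compound 3 `O=C(Nc1ccc2ccc(O)nc2c1)c1ccc(-c2ccccc2)cc1` differs from compound 2 by hydroxy in place of methyl on an aromatic carbon. Just one measured step bears on this change, and it shows that a single heavy atom entering at this aromatic carbon moved the number a long way; no measured step shows a hydroxy at the same carbon, so its own effect is unknown. The step from compound 2 to compound 3 is therefore expected to be small, no change at the digits printed from compound 2 to compound 3 (within the scatter), with a broad range in either direction. Compound 3 is estimated at 8 in this assay, between 7 and 9.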

Compound 3, negative logarithm of the antagonist equilibrium constant: 8.5
Estimate against measurement, compound 3: 0.50 log units below; the range from low to high includes it.
By their numbers in this assay, from the lowest: compound 2; then compound 3; then compound 1.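

The hydroxy result shows that this position, on an aromatic carbon next to the ring nitrogen, does not respond in one fixed way to a single heavy atom: in this assay, hydroxy in place of methyl gives a number 0.50 log units higher from compound 2 to compound 3 (beyond the scatter). Hydrogen still remains the best of the three groups, since hydroxy in place of hydrogen gives a number 0.90 log units lower from compound 1 to compound 3 (beyond the scatter), a smaller loss than methyl in place of hydrogen, which gives a number 1.40 log units lower from compound 1 to compound 2 (beyond the scatter). Nothing available explains why the two substituents part in this way.

The compounds shown leave open whether any group at this carbon can match hydrogen, with an amine, a methoxy group and a fluorine atom all untested here. They also leave open whether a longer chain such as ethyl would fall further than methyl.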